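The source may report more compounds than this note shows. Statements on the series, on what has been measured and on what is new or still open speak of the compounds shown alone.

Working notes on the series.

The shared core is set out by compound 1 `O=C1NC(=O)c2ccc(I)cc2/C1=C/Nc1ccc(CN2CCCCC2)cc1`, which in a functional assay on HCT-116 cells (Homo sapiens) for antiproliferative activity, read by sulforhodamine B assay (on this read-out higher numbers stand for weaker inhibition and lower numbers for stronger inhibition), gives 2700 nM. Going by the values given here, only one other number exists so far, and compound 1 stands at the upper end of the pair. Compound 2 `O=C1NC(=O)c2ccc(-c3ccoc3)cc2/C1=C/Nc1ccc(CN2CCCCC2)cc1` carries furan-3-yl where compound 1 carries iodo; in this assay compound 2 gives 1900 nM, a shift of a 1.4-fold lower number from compound 1 to compound 2 (0.15 log units; within the scatter).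

Compound 3 `O=C1NC(=O)c2ccc(-c3cccc(O)c3)cc2/C1=C/Nc1ccc(CN2CCCCC2)cc1` awaits measurement in this assay. Set against compound 1, the difference is 3-hydroxyphenyl in place of iodo on an aromatic carbon. Among the compounds with values here, the one step that bears on this change is the one from compound 1 to compound 2, in which an aromatic ring replaced the same iodo at the same position; that step was a 1.4-fold lower number from compound 1 to compound 2 (0.15 log units; within the scatter). On that basis a comparable outcome is expected for a second aromatic ring: at most a small shift toward a lower number, and quite possibly none beyond the scatter. Within the data shown here, nothing in the two numbers so far points to a large step in either direction.

For compound 3 the number in this assay is therefore estimated at 1500 nM, with a range of 500 nM to 4500 nM. That estimate amounts to an expected step of a 1.8-fold lower number from compound 1 to compound 3 (0.26 log units; within the scatter).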

Compound 3, half-maximal inhibitory concentration: 1300 nM
Compound 3: middle estimate off by 1.2-fold (0.06 log units), on the high side; low and high end bracket the measured number.
By their numbers in this assay, from the lowest: compounds 3, 2 and 1 (each within the scatter of the next, the first and the last beyond it).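

In this assay, going by these compounds alone, the change gives the first step at this aromatic carbon that lies beyond the scatter: a 2.1-fold lower number from compound 1 to compound 3 (0.32 log units; beyond the scatter) is modest, but it shows that 3-hydroxyphenyl, with its 7 heavy atoms, can take the place of iodo here with no loss in this read-out. The step of a 1.5-fold lower number from compound 2 to compound 3 (0.16 log units; within the scatter) stays within the scatter, so 3-hydroxyphenyl and furan-3-yl cannot be ordered, and nothing can be credited to the hydrogen-bond donor that enters with 3-hydroxyphenyl. No measurement at hand explains the step from iodo to 3-hydroxyphenyl.

The compounds shown leave open whether the hydroxyl of compound 3 contributes at all, a question that a plain phenyl, or a phenyl carrying an amine or a carboxylic acid in place of the hydroxyl, would address. Also open, from the compounds shown here alone, is whether an aromatic ring is needed on this carbon at all, as against a saturated morpholine or a longer alkyl chain, and whether any group here can produce a step larger than this modest one.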